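Pyrazole amide series: cyclohexenyl amide in place of aryl amide

The compounds below may be only part of what the source reports. "The series", "measured", "known", "first", "only" and "open" are said of these compounds alone.

Compound 1 `O=C(Nc1cc(-c2ccccc2)nn1-c1ccccc1)c1ccc(C(F)(F)F)cc1` has been tested in an assay on HEK293 cells for displacement of a labelled ligand from metabotropic glutamate receptor 5 (Rattus norvegicus) (on this read-out higher numbers stand for weaker inhibition and lower numbers for stronger inhibition), and gives 990 nM. Of the values recorded so far this is the higher number: compound 2 `N#Cc1cccc(C(=O)Nc2cc(-c3ccccc3)nn2-c2ccccc2Br)c1` gives 230 nM in this assay, and the gap between the two lies beyond the usual scatter. Compound 3 `O=C(Nc1cc(-c2ccccc2)nn1-c1ccccc1)C1=CCCCC1` has not yet been measured. It differs from compound 1 in one place, (cyclohex-1-en-1-yl in place of 4-(trifluoromethyl)phenyl on a carbonyl carbon). For the measured compounds named here, no measured pair shows a change of this kind, so nothing here tells how large a step to expect. The expectation is that the step from compound 1 to compound 3 in this assay is upward, towards weaker inhibition, and lies beyond the scatter, the estimated step being a 3.0-fold higher number from compound 1 to compound 3 (0.48 log units; beyond the scatter). For compound 3 the estimated inhibition constant is 3000 nM, with an expected range from 1000 nM to 12000 nM.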

Compound 3, inhibition constant: 4470 nM
Compound 3: middle estimate off by 1.5-fold (0.17 log units), on the low side; measured number inside the range.
By their numbers in this assay, from the lowest: compound 2; then compound 1; then compound 3.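

In this assay, for the compounds shown here, this is the first measured change at the group on a carbonyl carbon whose other neighbour is the amide-type nitrogen: cyclohex-1-en-1-yl in place of 4-(trifluoromethyl)phenyl gives a 4.5-fold higher number from compound 1 to compound 3 (0.65 log units; beyond the scatter). The position therefore responds to this replacement, although the weaker compound 3 still gives a measurable 4470 nM. No available measurement explains the step.

The single change removes the aromatic ring and all three fluorine atoms together and also lowers the heavy-atom count, so the compounds shown cannot assign the step to any one of these differences. Open questions are how an unsubstituted phenyl or a saturated cyclohexyl would read at this carbonyl carbon, and whether a 4-chlorophenyl would stand closer to compound 1 or compound 3.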